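A few compounds are considered here, and "the series" means these few. Any claim that something is new, unique, unknown or untested is made for them only; others in the source may bear on it.

In a physicochemical assay for solubility, at pH 1.1 (a lower number here means a less soluble compound, a higher number a more soluble compound), compound 1 (`CCCN(Cc1ccc(OCCn2c(=O)ccn(C)c2=O)c(C)c1)C(CC(=O)O)c1ccc(Cl)cc1`) gives 3000000 nM and compound 2 (`CCCN(Cc1ccc(OCCn2c(=O)ccn(C)c2=O)c(OC)c1)C(CC(=O)O)c1ccc(Cl)cc1`) gives 3000000 nM, so compound 2 stands level with compound 1. Compound 3 (`CCCCN(Cc1ccc(OCCn2c(=O)ccn(C)c2=O)c(OC)c1)C(CC(=O)O)c1ccc(Cl)cc1`) carries one change from compound 2, (methyl in place of hydrogen on a saturated chain carbon, three bonds along the chain from an amine nitrogen), which turns propyl into butyl. Among the measured compounds shown here, the only measured step shows no change at the digits printed from compound 1 to compound 2 (within the scatter) for methoxy in place of methyl on an aromatic carbon. That is a different change and a weak guide, but with it alone, no step beyond the scatter is expected in this assay. The expected step is no change at the digits printed from compound 2 to compound 3 (within the scatter). For compound 3 the estimate is 3000000 nM, with an expected range of 1200000 nM to 4500000 nM.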

Compound 3, solubility: 3000000 nM
Estimate against measurement, compound 3: no gap at the digits printed; low and high end bracket the measured number.
By their numbers in this assay, from the lowest: compounds 1, 2 and 3 (each within the scatter of the next).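

Going from propyl to butyl is the first change shown at this position, and in this assay it gives no change at the digits printed from compound 2 to compound 3 (within the scatter). The added methyl, three bonds along the chain from an amine nitrogen, therefore makes no readable difference here, whereas the earlier step concerned a different place on the shared core. No measurement shown explains this result. On these data alone, whether a longer chain such as pentyl would also read level remains open. The same goes for a chain ending in an amine or a carboxylic acid.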